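This account rests on a few compounds, and the source may have more. Where it says the series, first, only, none or still open, it means among the compounds named here.

The series shares one core, shown in compound 1 `O=C(Nc1ccccc1)c1csc(Cc2c(Cl)cccc2Cl)n1`, whose amide-type nitrogen carries a phenyl. Compound 2 `N#Cc1ccc(NC(=O)c2csc(Cc3c(Cl)cccc3Cl)n2)cc1` carries a 4-cyanophenyl there, and compound 3 `COc1ccc(NC(=O)c2csc(Cc3c(Cl)cccc3Cl)n2)cn1` a 6-methoxypyridin-3-yl. In an assay on CHO cells, read by calcium flux (a lower number here means a stronger inhibitor, a higher number a weaker inhibitor), compound 1 gives only a limit, > 4000 nM. In this assay compound 2 gives 720 nM. For compound 3, this assay likewise reports only a limit, > 4000 nM. Compound 3 therefore stands at the limit (the limit of > 4000 nM in this assay, at which 2 of the 3 values shown sit), together with compound 1, and has no number of its own; the step of an at least 5.5-fold higher number from compound 2 to compound 3 (0.74 log units; beyond the scatter) is readable, whereas the comparison a step that the two limits leave unreadable from compound 1 to compound 3.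

Compound 4 `O=C(Nc1ccccc1Br)c1csc(Cc2c(Cl)cccc2Cl)n1` is the next step: 2-bromophenyl in place of 6-methoxypyridin-3-yl on an amide-type nitrogen. The measured steps that bear on this position are an at least 5.5-fold lower number from compound 1 to compound 2 (0.74 log units; beyond the scatter) and an at least 5.5-fold higher number from compound 2 to compound 3 (0.74 log units; beyond the scatter). Both show that the group on the amide-type nitrogen can move the number by a modest amount or more, and only the 4-cyanophenyl of compound 2 has so far given a readable value. A 2-bromophenyl, without the cyano of compound 2, is expected to land nearer the limit shared by compound 1 and compound 3. For compound 4 the expected value in this assay is 3500 nM, within a range from 800 nM to 12000 nM. The step of an at least 1.1-fold lower number from compound 3 to compound 4 (0.05 log units; that floor lies within the scatter) is expected to be small, if readable at all.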

Compound 4, half-maximal inhibitory concentration: > 4000 nM
Compound 4: only a limit was reported; the forecaster's own chance of this, stated with the estimate: 55%; at least 1.1-fold (0.05 log units) between middle value and limit.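

In this assay, the 2-bromophenyl on the amide-type nitrogen gives no number of its own, and compound 4 joins compound 1 and compound 3 at a limit: the limit of > 4000 nM in this assay, at which 3 of the 4 values shown sit.

The one readable comparison is an at least 5.5-fold higher number from compound 2 to compound 4 (0.74 log units; beyond the scatter), so among the groups shown, the 2-bromophenyl does not give what the 4-cyanophenyl gives. The steps to compound 4 from compound 1 and from compound 3 cannot be read, as both ends are limits, so any effect of bromo in place of hydrogen stays hidden, and compound 1, compound 3 and compound 4 cannot be ranked against one another.

Compound 2 thus remains the only one of the four with a measured number, and a substituent on the phenyl does not by itself bring a compound to a readable value, as compound 4 shows. Going by these compounds, it remains open whether the cyano group itself matters or also the place it holds on the ring, and whether an amine or a carboxylic acid in place of that cyano would give a readable value.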